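Benzyl removal on the indole nitrogen: working notes

The source may hold more compounds than are shown below. What is called first, only, known or untested is meant among the compounds shown, and "the series" means these compounds.

Measured compounds:
Compound 1, `Cc1cc(C)c2nc(-c3cc4ccccc4n3Cc3ccccc3)[nH]c2c1`: 21800 nM
Compound 3, `Cc1cc(C)c2nc(-c3cc4ccccc4[nH]3)[nH]c2c1`: 24800 nM
Compound 2, `Brc1cnc2[nH]c(-c3cc4ccccc4n3Cc3ccccc3)nc2c1`: "not determined" (no result reported)

In a functional assay on T47D cells (Homo sapiens) for antiproliferative activity, read by MTT assay, with a stated time of 48 h (a lower number here means a stronger inhibitor, a higher number a weaker inhibitor), compound 1 gives 21800 nM, while compound 3 gives 24800 nM. The two share a core and differ by hydrogen in place of benzyl on an aromatic nitrogen; that change produced a 1.1-fold higher number from compound 1 to compound 3 (0.06 log units; within the scatter), so the benzyl on the indole nitrogen is not what sets the number in this pair.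

Compound 2 carries a different core; the difference between the two cores is not broken down here, and for compound 2 the entry in this assay reads "not determined" (no result reported). Compound 4, `Brc1cnc2[nH]c(-c3cc4ccccc4[nH]3)nc2c1`, stands to compound 2 as compound 3 stands to compound 1: hydrogen in place of benzyl on an aromatic nitrogen, at a place described in the same words, so this is the same change. The step from compound 2 to compound 4 in this assay is expected to be of about the size seen before, resting on a 1.1-fold higher number from compound 1 to compound 3 (0.06 log units; within the scatter). With no number for compound 2, the estimate for compound 4 leans on compound 3, because the only measured hydrogen-bearing indole is compound 3 at 24800 nM. Compound 4 is therefore expected near 25000 nM, estimated between 6000 nM and 100000 nM.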

Compound 4, half-maximal inhibitory concentration: 21000 nM
The estimate for compound 4 lay 1.2-fold (0.08 log units) above the measured number; the measured number falls inside the stated range.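

With no single number for compound 2 in this assay, the step from compound 2 to compound 4 cannot be read. The compounds shown leave open whether hydrogen in place of benzyl on an aromatic nitrogen acts on the core of compound 2 as it does on the core of compound 1. Nothing at hand offers an explanation for the value of compound 4.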